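Trimming a Piperidine Tail From an Amide Nitrogen

The compounds below may be only part of what the source reports. "The series", "measured", "known", "first", "only" and "open" are said of these compounds alone.

Of the compounds shown here, three sharing one core have been tested in a functional assay on A2058 cells (Homo sapiens) for antiproliferative activity, read by luminescence and CellTiter-Glo, with a stated time of 96 h; on this read-out higher numbers stand for weaker inhibition and lower numbers for stronger inhibition. Compound 1 (`O=C(Nc1ccc(F)cc1)c1n[nH]cc1NC(=O)c1c(F)ccc(-c2ccc(F)nc2)c1F`) gives 6310 nM, compound 2 (`O=C(Nc1ccc(F)cc1)c1n[nH]cc1NC(=O)c1c(F)ccc(-c2ccccc2)c1F`) gives 2370 nM, and compound 3 (`CN1CCC(CNC(=O)c2cccc(-c3ccc(F)c(C(=O)Nc4c[nH]nc4C(=O)Nc4ccc(F)cc4)c3F)c2)CC1`) gives 3340 nM. Compound 3 thus holds the second highest of the three numbers, and its gaps to compound 2 and to compound 1 both sit within the scatter of this assay, so the three cannot be ranked against each other with confidence. Compound 4 (`NC(=O)c1cccc(-c2ccc(F)c(C(=O)Nc3c[nH]nc3C(=O)Nc3ccc(F)cc3)c2F)c1`) differs from compound 3 by hydrogen in place of (1-methylpiperidin-4-yl)methyl on an amide-type nitrogen. Among the compounds with values here, no measured pair mirrors this exact change. The closest guide is a 1.4-fold higher number from compound 2 to compound 3 (0.15 log units; within the scatter), where the whole ((1-methylpiperidin-4-yl)methyl)carbamoyl group was added and barely moved the number. Since adding the full group did little, removing only its (1-methylpiperidin-4-yl)methyl part is expected to do little as well, with a step of a 1.1-fold lower number from compound 3 to compound 4 (0.05 log units; within the scatter). Compound 4 is therefore estimated at 3000 nM, within a range from 1200 nM to 8000 nM.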

Compound 4, half-maximal inhibitory concentration: 1990 nM
The estimate for compound 4 lay 1.5-fold (0.18 log units) above the measured number; low and high end bracket the measured number.
By their numbers in this assay, from the lowest: compounds 4, 2, 3 and 1 (each within the scatter of the next, the first and the last beyond it).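

Taking the (1-methylpiperidin-4-yl)methyl part off the amide-type nitrogen leaves a bare carbamoyl, and a 1.7-fold lower number from compound 3 to compound 4 (0.22 log units; within the scatter) stays within the scatter of this assay, so this ring-bearing tail is not needed for the activity seen here. The bare carbamoyl in place of hydrogen also gives only a 1.2-fold lower number from compound 2 to compound 4 (0.08 log units; within the scatter) and stays within the scatter, whereas 3-carbamoylphenyl in place of 6-fluoropyridin-3-yl gives a 3.2-fold lower number from compound 1 to compound 4 (0.50 log units; beyond the scatter) and is a modest step beyond it. No measured evidence bearing on these results is available.

From the compounds shown here alone, whether a small group on the same nitrogen, such as methyl or a 2-(dimethylamino)ethyl chain, would shift the number remains open. So does the effect of a carboxylic acid or a nitrile in place of the carbamoyl.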